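Amide chain extension in the methoxyphenylalkyl amide series

This account rests on a few compounds, and the source may have more. Where it says the series, first, only, none or still open, it means among the compounds named here.

Among the measured compounds shown here, compound 1 `COc1cccc(CCCNC(C)=O)c1` and compound 2 `CCC(=O)NCCCCc1cccc(OC)c1` share a core and differ in more than one place, so no single step connects them. In an assay for binding affinity to melatonin receptor (Gallus gallus) (on this read-out higher numbers stand for weaker inhibition and lower numbers for stronger inhibition), compound 1 gives 63 nM and compound 2 gives 119 nM; compound 2 holds the highest of the two numbers, with a gap to compound 1 that lies within the scatter. Compound 3 `CCCCC(=O)NCCCCc1cccc(OC)c1` awaits measurement in this assay. It differs from compound 2 by ethyl in place of hydrogen on a saturated chain carbon, two bonds along the chain from a carbonyl carbon, read one bond further out as propanoyl to butylcarbonyl. For the measured compounds named here, no measured step covers this change; a step of modest size is expected, if beyond the scatter at all, most likely toward a higher number. Compound 3 is expected at 160 nM in this assay, within 50 nM to 500 nM. That estimate means an expected 1.3-fold higher number from compound 2 to compound 3 (0.13 log units; within the scatter).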

Compound 3, inhibition constant: 9670 nM
For compound 3 the middle estimate is 60-fold (1.78 log units) below the measured one; measured number above the stated range.
By their numbers in this assay, from the lowest: compounds 1 and 2 (each within the scatter of the next); then compound 3.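

In this assay, ethyl in place of hydrogen on a saturated chain carbon, two bonds along the chain from a carbonyl carbon, gives a large loss, an 81-fold higher number from compound 2 to compound 3 (1.91 log units; beyond the scatter), so this position does not accept every chain extension. Compound 1 and compound 2 gave no reading of this position. Nothing shown accounts for the size of this step.

Open, going by these compounds, is whether methyl at the same place, giving a butanoyl amide, keeps the number of compound 2 or already shows part of the loss. Also open, on these data alone, is how a longer chain or a cyclopropyl group would read here.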